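A few compounds are considered here, and "the series" means these few. Any claim that something is new, unique, unknown or untested is made for them only; others in the source may bear on it.

Measured in a functional assay (aorta) with Rattus norvegicus as the target, in the presence of a further agent that is not named here; a higher number here means that more compound is needed for the effect, a lower number that less compound is needed:
compound 1 `COC(=O)C1=C(C)N=C(C)/C(=C(/O)OC)C1c1cccc(OCc2c(C)no[n+]2[O-])c1`: 400 nM
compound 2 `COC(=O)C1=C(C)N=C(C)/C(=C(/O)OC)C1c1cccc(OCc2nonc2C(N)=O)c1`: 3500 nM
compound 3 `COC(=O)C1=C(C)N=C(C)/C(=C(/O)OC)C1c1ccccc1OCc1c(C)no[n+]1[O-]`: 78 nM

Compound 3 has the lowest of these numbers, so it needs the least compound for the effect. Compound 4 `COC(=O)C1=C(C)N=C(C)/C(=C(/O)OC)C1c1ccccc1OCc1nonc1C#N` alters one group of compound 3: a group of 7 heavy atoms (3 carbon, 3 nitrogen, 1 oxygen; one five-membered aromatic ring with 3 hetero atoms) in place of a group of 7 heavy atoms (3 carbon, 2 nitrogen, 2 oxygen; one five-membered aromatic ring with 3 hetero atoms), on a saturated chain carbon bound to an oxygen on an aromatic ring. The entering group is 4-cyano-1,2,5-oxadiazol-3-yl. Among the measured compounds shown here, only one measured step bears on this change: an 8.8-fold higher number from compound 1 to compound 2 (0.94 log units; beyond the scatter). In that step the same group leaves from the same kind of place, although a different group enters. Going by that single modest step, a rise of similar size is expected in this assay. The expected step is a 7.1-fold higher number from compound 3 to compound 4 (0.85 log units; beyond the scatter). For compound 4 the estimated value is 550 nM, with an expected range of 150 nM to 2000 nM.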

Compound 4, half-maximal effective concentration: 6.6 nM
Compound 4: the middle estimate sits 83-fold (1.92 log units) above what was measured, and the stated range ends above it.
By their numbers in this assay, from the lowest: compound 4; then compound 3; then compound 1; then compound 2.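

In this assay, among the compounds shown here, putting 4-cyano-1,2,5-oxadiazol-3-yl on this saturated chain carbon lowers the number (a 12-fold lower number from compound 3 to compound 4 (1.07 log units; beyond the scatter)), so losing the departing group does not always raise it, as the one earlier step might suggest (an 8.8-fold higher number from compound 1 to compound 2 (0.94 log units; beyond the scatter)). Those two steps differ in the entering group and in where the chain sits on the aromatic ring, and the compounds shown cannot separate these two differences. No measurement here accounts for the drop.

From the compounds shown here alone, it remains open whether 4-cyano-1,2,5-oxadiazol-3-yl gives a similar step with the chain placed as in compound 1. Going by these compounds, it is also open whether a carboxylic acid in place of the nitrile would keep the number this low.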